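Furan replacements for the thiophene in the chemokine receptor series

This account rests on a few compounds, and the source may have more. Where it says the series, first, only, none or still open, it means among the compounds named here.

Measured so far:
compound 1 `CC[C@@H](Nc1c(Nc2cccc(C(=O)N(C)C)c2O)c(=O)c1=O)c1cc(C)cs1`: 24 nM
compound 2 `CC[C@@H](Nc1c(Nc2cccc(C(=O)N(C)C)c2O)c(=O)c1=O)c1sccc1C`: 123 nM
compound 3 `CCC(C)c1coc([C@@H](CC)Nc2c(Nc3cccc(C(=O)N(C)C)c3O)c(=O)c2=O)c1`: 7.6 nM

All three were run in an assay on CHO cells for displacement of a labelled ligand from C-X-C chemokine receptor type 1 (Homo sapiens); on this read-out higher numbers stand for weaker inhibition and lower numbers for stronger inhibition. Compound 1 stands second highest of the three numbers: a 5.1-fold higher number from compound 1 to compound 2 (0.71 log units; beyond the scatter) goes to a higher number, a 3.2-fold lower number from compound 1 to compound 3 (0.50 log units; beyond the scatter) to a lower one, and a 16-fold lower number from compound 2 to compound 3 (1.21 log units; beyond the scatter) spans the full range. The unmeasured compound 4 `CC[C@@H](Nc1c(Nc2cccc(C(=O)N(C)C)c2O)c(=O)c1=O)c1cc(C2CCCCC2)co1` differs from compound 1 in one place: 4-cyclohexylfuran-2-yl in place of 4-methylthiophen-2-yl on a saturated chain carbon bound to a nitrogen on an aromatic ring and a saturated chain carbon. The step that bears on it is a 3.2-fold lower number from compound 1 to compound 3 (0.50 log units; beyond the scatter), where 4-(sec-butyl)furan-2-yl likewise replaced 4-methylthiophen-2-yl at the same place; compound 4 again puts a substituted furan-2-yl there. A step of similar size toward a lower number is therefore expected, a 3.4-fold lower number from compound 1 to compound 4 (0.54 log units; beyond the scatter). Compound 4 is estimated at 7 nM (range 2.5 nM to 20 nM).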

Compound 4, inhibition constant: 283 nM
For compound 4 the middle estimate is 40-fold (1.61 log units) below the measured one; measured number outside the range, above it.
By their numbers in this assay, from the lowest: compound 3; then compound 1; then compound 2; then compound 4.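

At this position a substituted furan-2-yl does not carry the gain by itself: with cyclohexyl in place of sec-butyl on an aromatic carbon, the series shows a 37-fold higher number from compound 3 to compound 4 (1.57 log units; beyond the scatter), so the result depends on the furan substituent. The 4-cyclohexylfuran-2-yl also falls behind both thiophenes, with a 12-fold higher number from compound 1 to compound 4 (1.07 log units; beyond the scatter) and a 2.3-fold higher number from compound 2 to compound 4 (0.36 log units; beyond the scatter). No measurement on hand accounts for this reversal.

Open, going by these compounds, is whether a smaller ring such as cyclopropyl or an open chain such as n-butyl on the furan would hold the level of compound 3. The sec-butyl stereoisomers also remain unresolved in the compounds shown.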